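The source may report more compounds than this note shows. Statements on the series, on what has been measured and on what is new or still open speak of the compounds shown alone.

Notes on the series in a functional assay on RPMI-8226 cells (Homo sapiens) for inhibition, read by sulforhodamine B assay, with a stated time of 48 h; on this read-out lower numbers stand for stronger inhibition and higher numbers for weaker inhibition. For the measured compounds named here, compound 2 `COc1cc(-c2nn(-c3cccc(NC(=O)Nc4ccc(Cl)c(Cl)c4)c3)cc2-c2ccncc2)ccc1Cl` gives 390 nM in this assay and stands lowest of the two numbers so far. Compound 1 `O=C(Nc1cccc(-n2cc(-c3ccncc3)c(-c3ccc(Cl)c(O)c3)n2)c1)Nc1cccc(C(F)(F)F)c1` gives 1340 nM in this assay, a higher number than compound 2, and the gap lies beyond the scatter. Compound 3 `O=C(Nc1cccc(-n2cc(-c3ccncc3)c(-c3ccc(Cl)c(O)c3)n2)c1)Nc1ccc(Cl)c(Cl)c1` is the next entry: the change from compound 2 is hydrogen in place of methyl on an oxygen on an aromatic ring. Going by the values given here, no measured pair isolates this change, so no step is known for it. The expected step from compound 2 to compound 3 is a 1.5-fold higher number from compound 2 to compound 3 (0.19 log units; within the scatter), toward a somewhat higher number. Compound 3 is estimated at 600 nM, with a range of 250 nM to 1500 nM.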

Compound 3, half-maximal inhibitory concentration: 1030 nM
Estimate against measurement, compound 3: 1.7-fold (0.23 log units) below, within the range that was stated.
By their numbers in this assay, from the lowest: compound 2; then compounds 3 and 1 (each within the scatter of the next).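

In this assay, removing the methyl from methoxy costs potency: hydrogen on that oxygen gives a 2.6-fold higher number from compound 2 to compound 3 (0.42 log units; beyond the scatter) and so the 4-chloro-3-methoxyphenyl form is preferred in this pair. With 4-chloro-3-hydroxyphenyl held fixed, 3,4-dichlorophenyl in place of 3-(trifluoromethyl)phenyl gives a 1.3-fold lower number from compound 1 to compound 3 (0.11 log units; within the scatter) and so does not separate these two groups. No supporting data explain the methoxy step. Open, as far as these compounds go, is whether the methoxy preference holds alongside 3-(trifluoromethyl)phenyl, and how ethoxy or an amine would behave on that ring.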